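The compounds below may be only part of what the source reports. "The series", "measured", "known", "first", "only" and "open" are said of these compounds alone.

Compound 2 `CC1=NC(C)=C(C(=O)O)C(c2cccnc2)/C1=C(\O)OC/C=C/c1ccccc1` gives 24000 nM in a functional assay on IMR-32 cells for inhibition of Voltage-dependent N-type calcium channel subunit alpha-1B (Homo sapiens), read by calcium flux (a higher number here means a weaker inhibitor, a lower number a stronger inhibitor), and stands within the scatter of compound 1 `CC1=NC(C)=C(C(=O)O)C(c2cccc(C(=O)O)c2)/C1=C(\O)OC/C=C/c1ccccc1`, which in this assay gives 37000 nM. Compound 3 `CC1=NC(C)=C(C(=O)O)C(c2ccoc2)/C1=C(\O)OC/C=C/c1ccccc1` differs from compound 2 by furan-3-yl in place of pyridin-3-yl on a saturated ring carbon. Going by the values given here, only one measured step touches that position, a 1.5-fold lower number from compound 1 to compound 2 (0.19 log units; within the scatter), and it stayed within the scatter; it swapped a different pair of rings, so it bears on this change only loosely. Compound 3 is therefore expected to show no step beyond the scatter, a 1.0-fold higher number from compound 2 to compound 3 (0.02 log units; within the scatter). Compound 3 is estimated at 25000 nM, with a range from 9000 nM to 70000 nM.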

Compound 3, half-maximal inhibitory concentration: 11000 nM
Compound 3: middle estimate off by 2.3-fold (0.36 log units), on the high side; low and high end bracket the measured number.
By their numbers in this assay, from the lowest: compound 3; then compounds 2 and 1 (each within the scatter of the next).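

In this assay, going by these compounds alone, this position does respond to the ring it carries: furan-3-yl brings a 2.2-fold lower number from compound 2 to compound 3 (0.34 log units; beyond the scatter) and also a 3.4-fold lower number from compound 1 to compound 3 (0.53 log units; beyond the scatter), the first steps here beyond the scatter, whereas compound 1 and compound 2 had not separated. The five-membered ring thus reads apart from both six-membered aromatic rings, though only modestly. Nothing at hand accounts for this difference.

Going by these compounds, whether thiophen-3-yl or furan-2-yl would match furan-3-yl stays open. So does whether the step would hold with a methyl ester in place of the carboxy group next to this carbon.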